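The source may report more compounds than this note shows. Statements on the series, on what has been measured and on what is new or still open speak of the compounds shown alone.

Compound 2 `Cc1noc(CNC(=O)c2ccc(C)c(S(=O)(=O)Nc3ccc(Cl)cc3)c2)n1` and compound 1 `Cc1ccc(NS(=O)(=O)c2cc(C(=O)NCc3nc(C)no3)ccc2C)cc1` share one core and differ in a single ring substituent. In an ADME assay on MDCK-II cells (Canis lupus familiaris) for permeability (a lower number here means that the compound crosses the layer more slowly, a higher number that the compound crosses the layer faster), compound 1 gives 20 10^-6 cm/s, and in the same assay compound 2 gives 19 10^-6 cm/s; the step of a 1.1-fold lower number from compound 1 to compound 2 (0.02 log units; within the scatter) shows the two numbers sit together, so compound 2 stands level with compound 1 rather than apart from it. Compound 3 `Cc1ccc(C(=O)NCc2cn(C)nn2)cc1S(=O)(=O)Nc1ccc(Cl)cc1` has not yet been measured in this assay. It differs from compound 2 by 1-methyl-1H-1,2,3-triazol-4-yl in place of 3-methyl-1,2,4-oxadiazol-5-yl on a saturated chain carbon bound to an amide-type nitrogen. Among the measured compounds shown here, no measured step touches this part of the molecule: the only step known swaps a group on an aromatic carbon elsewhere, and it stayed within the scatter. With nothing that speaks for a shift, compound 3 is expected to show a step of a 1.1-fold lower number from compound 2 to compound 3 (0.05 log units; within the scatter) that does not exceed the scatter. Compound 3 is therefore estimated at 17 10^-6 cm/s, with a range from 8 10^-6 cm/s to 35 10^-6 cm/s.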

Compound 3, apparent permeability: 19 10^-6 cm/s
Beside the measured number, compound 3's estimate is 1.1-fold (0.05 log units) below it, and the stated range covers the measured number.
By their numbers in this assay, from the lowest: compounds 2, 3 and 1 (each within the scatter of the next).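

In this assay, among the compounds shown here, putting 1-methyl-1H-1,2,3-triazol-4-yl in place of 3-methyl-1,2,4-oxadiazol-5-yl on a saturated chain carbon bound to an amide-type nitrogen gives no change at the digits printed from compound 2 to compound 3 (within the scatter) as its result, the first measured step at this position. The two groups match in what is counted here: each has 6 heavy atoms, one five-membered aromatic ring with 3 hetero atoms, 0 hydrogen-bond donors, 3 hydrogen-bond acceptors and no net charge, so this step tests a change of ring atoms with those counts held the same. Nothing available explains why the number holds.

What the compounds shown leave open is whether the number would also hold with a group that breaks those counts, such as a carboxylic acid or an amine, at this place. Also open, from the compounds shown here alone, is whether a longer chain carrying either ring would behave in the same way.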